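Hydroxy in place of methoxy on a pyrazole urea series

The compounds below may be only part of what the source reports. "The series", "measured", "known", "first", "only" and "open" are said of these compounds alone.

Of the compounds shown here, two of a shared core have been tested in a functional assay on LOX IMVI cells (Homo sapiens) for inhibition, read by sulforhodamine B assay, with a stated time of 48 h; on this read-out higher numbers stand for weaker inhibition of growth and lower numbers for stronger inhibition of growth. Compound 1 `O=C(Nc1cccc(-n2cc(-c3ccncc3)c(-c3ccc(Cl)c(O)c3)n2)c1)Nc1cccc(C(F)(F)F)c1` gives 9580 nM. Compound 2 `COc1cc(-c2nn(-c3cccc(NC(=O)Nc4cc(C(F)(F)F)cc(C(F)(F)F)c4)c3)cc2-c2ccncc2)ccc1Cl` gives 1520 nM, the lower of the two numbers, and the gap to compound 1 lies beyond the scatter. Among the measured compounds shown here, compound 1 and compound 2 differ in two places at once, so no single step between them can be read off.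

Compound 3 `O=C(Nc1cccc(-n2cc(-c3ccncc3)c(-c3ccc(Cl)c(O)c3)n2)c1)Nc1cc(C(F)(F)F)cc(C(F)(F)F)c1` is the next compound to be measured in this assay . It differs from compound 2 in one place: hydrogen in place of methyl on an oxygen on an aromatic ring, a methoxy to hydroxy change on the 4-chloro-3-methoxyphenyl group. Compound 1 also carries the hydroxy, but its other difference clouds the comparison. In this assay the step from compound 2 to compound 3 is expected to be a modest move toward a higher number, of a 1.7-fold higher number from compound 2 to compound 3 (0.23 log units; within the scatter). Compound 3 is therefore estimated at 2600 nM, in a range from 900 nM to 7500 nM.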

Compound 3, concentration for total growth inhibition: 1400 nM
Compound 3: the middle estimate sits 1.9-fold (0.27 log units) above what was measured; the measured number falls inside the stated range.
By their numbers in this assay, from the lowest: compounds 3 and 2 (each within the scatter of the next); then compound 1.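

In this assay, the methoxy to hydroxy change on the 4-chloro-3-methoxyphenyl group gives a 1.1-fold lower number from compound 2 to compound 3 (0.04 log units; within the scatter), so in this setting the read-out does not distinguish the two groups. Compound 3 also provides the single-place link that compound 1 and compound 2 lacked: with the hydroxy held constant, trifluoromethyl in place of hydrogen on an aromatic carbon gives a 6.8-fold lower number from compound 1 to compound 3 (0.84 log units; beyond the scatter), so the gap between compound 1 and compound 2 follows the trifluoromethyl difference and not the methyl on the oxygen. Nothing available here explains either step.

Going by these compounds, it remains open whether an amine or an ethoxy group in place of the hydroxy would also read like the methoxy. On these data alone, it is also open whether the methoxy to hydroxy change would read the same on the core of compound 1, which carries one trifluoromethyl group fewer.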